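The compounds below may be only part of what the source reports. "The series", "measured", "known", "first", "only" and "open" are said of these compounds alone.

Compound 2 `COc1ccc(CN(c2cc(OC)c(OC)c(OC)c2)S(=O)(=O)c2ccccc2)cc1` carries a plain phenyl on the sulfonyl, and in a functional assay on PC-3 cells (Homo sapiens) for inhibition, read by MTT assay, with a stated time of 48 h (on this read-out lower numbers stand for stronger inhibition and higher numbers for weaker inhibition), its result is a limit, > 50000 nM, that is, (the limit of > 50000 nM in this assay, at which 1 of the 2 values shown sits). Compound 1 `COc1ccc(CN(c2cc(OC)c(OC)c(OC)c2)S(=O)(=O)c2ccc(C)cc2)cc1` differs from it only by a methyl on that ring and gives 8220 nM in this assay. The step of an at least 6.0-fold higher number from compound 1 to compound 2 (0.78 log units; beyond the scatter) shows that taking the methyl away weakens inhibition past the point where a number is read.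

Compound 3 `COc1ccc(CN(c2cc(OC)c(OC)c(OC)c2)S(=O)(=O)c2ccc(C(C)(C)C)cc2)cc1` moves the same ring the other way: tert-butyl in place of hydrogen on an aromatic carbon. For the measured compounds named here, the only measured step that bears on this change is the one from methyl to hydrogen, which lay beyond the scatter, and here a larger alkyl replaces the hydrogen rather than a smaller one. In this assay a lower number than the limit of compound 2 is therefore expected, with a step comparable in size to the one observed, though whether the tert-butyl tracks the methyl cannot be known from the two values at hand. The expected step is an at least 5.5-fold lower number from compound 2 to compound 3 (0.74 log units; beyond the scatter). Compound 3 is estimated at 9000 nM in this assay, within a range from 2000 nM to 50000 nM.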

Compound 3, half-maximal inhibitory concentration: 28600 nM
Estimate against measurement, compound 3: 3.2-fold (0.50 log units) below, within the range that was stated.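

Replacing the methyl with tert-butyl on this ring weakens inhibition in this assay with a 3.5-fold higher number from compound 1 to compound 3 (0.54 log units; beyond the scatter) as the printed step, so at this position the effect of an alkyl group does not simply carry over from methyl to tert-butyl. Putting tert-butyl in place of hydrogen gives an at least 1.7-fold lower number from compound 2 to compound 3 (0.24 log units; that floor lies within the scatter) as its step, and that floor alone does not establish that tert-butyl improves on hydrogen, although the true difference may be larger. Compound 2 has only a limit and not a number, so the size of this gain cannot be fixed, because the comparison starts from that limit: the limit of > 50000 nM in this assay, at which 1 of the 3 values shown sits.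

The three compounds place only hydrogen, methyl and tert-butyl at this position, which leaves open where an ethyl or isopropyl group would fall relative to methyl and tert-butyl. They also leave open whether a substituent of another kind, such as a methoxy group, a chlorine atom or a carboxylic acid, could match or exceed the methyl of compound 1 here.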